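The source may hold more compounds than are shown below. What is called first, only, known or untested is meant among the compounds shown, and "the series" means these compounds.

Measured so far:
- compound 1, `COc1ccc(CN(C(=O)CCl)c2cc(OC)c(OC)c(OC)c2)cc1O`: 210 nM
- compound 2, `C/C=C/C(=O)N(Cc1ccc(OC)c(Cl)c1)c1cc(OC)c(OC)c(OC)c1`: 10100 nM

Both compounds were tested in a functional assay on KYSE-450 cells (Homo sapiens) for inhibition, read by MTT assay, with a stated time of 48 h; on this read-out higher numbers stand for weaker inhibition and lower numbers for stronger inhibition. Compound 1 gives the lower of the two numbers, and the gap to compound 2 is well beyond the usual scatter of repeated measurements, so compound 1 is the stronger inhibitor of the pair. Compound 2 differs from compound 1 in more than one place at once, so its value alone does not tell which change is responsible for the weaker inhibition.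

The step considered here leads from compound 1 to compound 3, `C=CC(=O)N(Cc1ccc(OC)c(O)c1)c1cc(OC)c(OC)c(OC)c1`. Among the measured compounds shown here, the two share the same core and the same benzyl portion; the only change is vinyl in place of chloromethyl on a carbonyl carbon. For the measured compounds named here, no measured pair shows this exact change, so the expectation rests on compound 1 as the anchor and on the general observation that the one other compound carrying a double bond at this carbonyl, compound 2, is markedly weaker. Compound 3 is therefore expected to inhibit somewhat more weakly than compound 1, with an estimated step of a 2.9-fold higher number from compound 1 to compound 3 (0.46 log units; beyond the scatter), modest but likely beyond the scatter. The estimate for compound 3 in this assay is 600 nM, within a range of 150 nM to 3000 nM.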

Compound 3, half-maximal inhibitory concentration: 160 nM
Compound 3: the middle estimate sits 3.8-fold (0.57 log units) above what was measured; low and high end bracket the measured number.
By their numbers in this assay, from the lowest: compounds 3 and 1 (each within the scatter of the next); then compound 2.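

In this assay, putting vinyl in place of chloromethyl on the carbonyl carbon gives a 1.3-fold lower number from compound 1 to compound 3 (0.12 log units; within the scatter), so the two groups cannot be told apart at this position. Compound 3 carries no chlorine and has a double bond on this carbonyl carbon, yet it gives 160 nM; neither the chlorine of chloromethyl nor a saturated group here is needed to reach this level of inhibition, and a double bond at this position does not by itself bring a high number. No measurement shown explains why the two groups give such similar values.

Compound 2, at 10100 nM, differs from compound 1 and from compound 3 in more than one place, so its value cannot yet be assigned to the methyl end of its double bond, to its chlorine on the benzyl portion, or to the two together. Also open, as far as these compounds go, is how inhibition responds to a plain methyl or ethyl group on this carbonyl carbon, which has neither chlorine nor a double bond, or to an amine such as dimethylaminomethyl.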